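This account rests on a few compounds, and the source may have more. Where it says the series, first, only, none or still open, it means among the compounds named here.

Measured compounds:
compound 1, `c1ccc(N2CCc3oc(-c4ccccn4)nc3C2)cc1`, 330 nM in an assay on CHO cells for inhibition of metabotropic glutamate receptor 5 (Homo sapiens); a higher number here means a weaker inhibitor, a lower number a stronger inhibitor
compound 2, `N#Cc1cccc(N2CCc3nc(-c4ccccn4)oc3C2)c1`, 290 nM in this assay

Compound 2 has the lower of the two numbers, but its gap to compound 1 lies within the scatter, so the two are not separated on this evidence. Compound 3, `N#Cc1cc(F)cc(N2CCc3nc(-c4ccccn4)oc3C2)c1`, has not been measured in this assay. The change from compound 2 is fluoro in place of hydrogen on an aromatic carbon. Among the compounds with values here, no step between measured compounds covers such a change, so the expected step of a 1.2-fold lower number from compound 2 to compound 3 (0.06 log units; within the scatter) is small, with no direction beyond the scatter. For compound 3 the estimate is 250 nM, in the range 100 nM to 650 nM.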

Compound 3, half-maximal inhibitory concentration: 54 nM
The estimate for compound 3 lay 4.6-fold (0.67 log units) above the measured number; the measured number lies below the stated range.
By their numbers in this assay, from the lowest: compound 3; then compounds 2 and 1 (each within the scatter of the next).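

In this assay, fluoro in place of hydrogen on an aromatic carbon meta to a cyano group gives a 5.4-fold lower number from compound 2 to compound 3 (0.73 log units; beyond the scatter) and so separates compound 3 from compound 2, whereas compound 1 and compound 2 stay within the scatter of each other. This position therefore responds to a single added fluorine atom. Nothing at hand bears on the reason for this step.

Going by these compounds, whether chloro, methoxy or an amine at this position would give a step of similar size remains open. Also open, on these data alone, is whether the fluoro step depends on the cyano group being present.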